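Replacing Phenyl with 3-Methoxybenzyl: A Step Without Precedent

The source may report more compounds than this note shows. Statements on the series, on what has been measured and on what is new or still open speak of the compounds shown alone.

Three related compounds have been measured in an ADME assay on L02 cells (Homo sapiens) for inhibition, read by CCK-8 assay, with a stated time of 48 h; on this read-out higher numbers stand for weaker inhibition of growth and lower numbers for stronger inhibition of growth. Compound 1 `Cc1ccccc1Nc1nc(NC2CC2)ncc1Cl` reads > 100000 nM, which is a limit of the assay and not a number. Compound 2 `Cc1ccccc1Nc1nc(Nc2ccc(N3CCNCC3)cn2)ncc1Cl` gives 1850 nM. Compound 3 `CN1CCN(c2ccc(Nc3ncc(Cl)c(Nc4ccccc4)n3)nc2)CC1` gives 7990 nM, the higher of the two actual numbers, so it inhibits growth less strongly than compound 2, by more than the usual scatter.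

Compound 4 `COc1cccc(CNc2nc(Nc3ccc(N4CCN(C)CC4)cn3)ncc2Cl)c1` differs from compound 3 in one place, with 3-methoxybenzyl in place of phenyl on a nitrogen on an aromatic ring. Within the data shown here, no two measured compounds differ in only one place, so this assay offers no direct precedent for this change. The best starting point is compound 3 at 7990 nM, with no step beyond the scatter expected and neither direction favoured. The estimated step is a 1.1-fold higher number from compound 3 to compound 4 (0.05 log units; within the scatter). For compound 4 the expected value is 9000 nM, with an estimated range from 2500 nM to 32000 nM.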

Compound 4, concentration for 50% growth inhibition: 16200 nM
Compound 4: middle estimate off by 1.8-fold (0.26 log units), on the low side; the measured number falls inside the stated range.
By their numbers in this assay, from the lowest: compound 2; then compound 3; then compound 4. At a limit, above all of these: compound 1.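

In this assay, among these compounds, this is the first step that can be read at this position, on a nitrogen on an aromatic ring, and it points towards weaker inhibition of growth: a 2.0-fold higher number from compound 3 to compound 4 (0.31 log units; beyond the scatter). The step is modest, so exchanging anilino for (3-methoxybenzyl)amino moves the number without carrying compound 4 to a limit of the assay. Compound 1 alone sits at a limit, which is not a number: the limit of > 100000 nM in this assay, at which 1 of the 4 values shown sits.

The change alters two things at once, adding a carbon link between the nitrogen and the ring and adding a methoxy group, so a plain benzyl group or a 3-methoxyphenyl group on this nitrogen would be needed to tell their shares apart. Why the number rises also stays open, since nothing shown here gives a cause.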